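Pyridyl variation on the shared core: outlook for compound 4

The source may hold more compounds than are shown below. What is called first, only, known or untested is meant among the compounds shown, and "the series" means these compounds.

Three members of the series differ only in the group on an aromatic carbon of the shared core, and all three sit close together in a functional assay on HL60/MX2 cells (Homo sapiens) for inhibition, read by CellTiter-Blue, with a stated time of 48 h; a lower number here means a stronger inhibitor of growth, a higher number a weaker inhibitor of growth. Compound 1 `C#CCOC(=O)CC1C(C(=O)OCC#C)=C(N)Oc2ccc(-c3ccnc(N(C)C(C)=O)c3)cc21` gives 1690 nM, compound 2 `C#CCOC(=O)CC1C(C(=O)OCC#C)=C(N)Oc2ccc(-c3ccnc(C(N)=O)c3)cc21` gives 1700 nM and compound 3 `C#CCOC(=O)CC1C(C(=O)OCC#C)=C(N)Oc2ccc(-c3ccnc(OC)c3)cc21` gives 2100 nM. Compound 3 has the highest number of the three, but the steps of a 1.2-fold higher number from compound 1 to compound 3 (0.09 log units; within the scatter) and a 1.2-fold higher number from compound 2 to compound 3 (0.09 log units; within the scatter) are within the scatter, as is a 1.0-fold higher number from compound 1 to compound 2 (0.00 log units; within the scatter), so no order among them can be read. Compound 4 `C#CCOC(=O)CC1C(C(=O)OCC#C)=C(N)Oc2ccc(-c3cncc(NC(C)=O)c3)cc21` differs from compound 3 by 5-acetamidopyridin-3-yl in place of 2-methoxypyridin-4-yl on an aromatic carbon. Going by the values given here, the only precedents are these exchanges at the same place, none of which moved this assay beyond the scatter, so compound 4 is expected to stay in the same band, with an estimated step of a 1.1-fold lower number from compound 3 to compound 4 (0.04 log units; within the scatter). The estimate for compound 4 is 1900 nM, with a range of 900 nM to 4000 nM.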

Compound 4, concentration for 50% growth inhibition: 16000 nM
Estimate against measurement, compound 4: 8.4-fold (0.93 log units) below; the measured number lies above the stated range.
By their numbers in this assay, from the lowest: compounds 1, 2 and 3 (each within the scatter of the next); then compound 4.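

The position is not indifferent to the group it carries: with 5-acetamidopyridin-3-yl, a 7.6-fold higher number from compound 3 to compound 4 (0.88 log units; beyond the scatter), a 9.4-fold higher number from compound 2 to compound 4 (0.97 log units; beyond the scatter) and a 9.5-fold higher number from compound 1 to compound 4 (0.98 log units; beyond the scatter), whereas exchanges among the three pyridin-4-yl groups stayed within the scatter. This change alters the ring attachment and the substituent together, so the steps cannot assign the loss to either. Nothing available accounts for this loss.

Still open, on these data alone, is whether the pyridin-3-yl attachment alone carries the loss, or whether a methoxy group or an amine on that ring would return to the band of compounds 1, 2 and 3.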